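The source may hold more compounds than are shown below. What is called first, only, known or untested is meant among the compounds shown, and "the series" means these compounds.

Measured so far:
compound 1, `O=C(Nc1nc2ccccc2s1)c1cn(-c2ccccc2)nc1-c1ccccc1` — > 50000 nM
compound 2, `O=C(Nc1nc2ccccc2s1)c1cn(-c2ccccc2)nc1-c1ccc(F)cc1` — 33400 nM
compound 3, `O=C(Nc1nc2ccccc2s1)c1cn(-c2ccccc2)nc1-c1ccc(Cl)cc1` — not yet measured

In an ADME assay on HEK-293T cells (Homo sapiens) for cytotoxicity, read by MTT assay, with a stated time of 72 h (on this read-out lower numbers stand for stronger inhibition and higher numbers for weaker inhibition), compound 1 gives only a limit, > 50000 nM. In this assay, for the measured compounds named here, compound 2 gives 33400 nM, the one real number in this pair. Going by the values given here, the single measured step, an at least 1.4-fold lower number from compound 1 to compound 2 (0.17 log units; that floor lies within the scatter), rests on (the limit of > 50000 nM in this assay, at which 1 of the 2 values shown sits), so its true size is not fixed and its floor sits within the scatter.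

Compound 3 differs from compound 2 by chloro in place of fluoro on an aromatic carbon. Among the compounds with values here, no measured step involves a chloro group; the nearest guide is the fluoro step from compound 1 to compound 2, which was small. A modest lowering of the number is therefore expected, a 1.3-fold lower number from compound 2 to compound 3 (0.13 log units; within the scatter), but not clearly beyond the scatter. Compound 3 is estimated at 25000 nM in this assay, between 10000 nM and 60000 nM.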

Compound 3, half-maximal inhibitory concentration: 39600 nM
For compound 3 the middle estimate is 1.6-fold (0.20 log units) below the measured one; the range from low to high includes it.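

In this assay, the change from 4-fluorophenyl to 4-chlorophenyl gives a 1.2-fold higher number from compound 2 to compound 3 (0.07 log units; within the scatter), so chloro and fluoro on this aromatic carbon, para to a large group, cannot be told apart on this read-out. Compound 1 gives > 50000 nM, which is a limit and not a number. Against hydrogen, the chloro change reads only as an at least 1.2-fold lower number from compound 1 to compound 3 (0.10 log units; that floor lies within the scatter), and its true size cannot be fixed: the limit of > 50000 nM in this assay, at which 1 of the 3 values shown sits.

From the compounds shown here alone, whether an amine, a methoxy group or a carboxylic acid at this place would move the number beyond the scatter remains open. Also open, going by these compounds, is whether chloro in place of fluoro elsewhere on the shared core would read the same way.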